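The source may hold more compounds than are shown below. What is called first, only, known or untested is meant among the compounds shown, and "the series" means these compounds.

Measured in a functional assay on K562 cells (Homo sapiens) for cytotoxicity, read by fluorescence, with a stated time of 72 h; a higher number here means a weaker inhibitor, a lower number a stronger inhibitor:
- Compound 1 `CSc1nc(NCc2ccc(-c3ccccn3)cc2)c2[nH]nc(C(C)C)c2n1`: 778 nM
- Compound 2 `CC(C)c1n[nH]c2c(NCc3ccc(-c4ccccn4)cc3)nc(S(C)(=O)=O)nc12`: 640 nM
- Compound 3 `CC(C)c1n[nH]c2c(NCc3ccc(-c4ccccn4)cc3)nc(NCCN)nc12`: 63 nM

Compound 3, at 63 nM, has the lowest number of the three, and its steps to the other two lie beyond the scatter. Compound 4 `CC(C)c1n[nH]c2c(NCc3ccc(-c4ccccn4)cc3)nc(N[C@H]3CC[C@H](N)CC3)nc12`, not yet measured, carries 4-aminocyclohexyl in place of 2-aminoethyl on a nitrogen on an aromatic ring. Three measured steps are nearby. The change a 1.2-fold lower number from compound 1 to compound 2 (0.08 log units; within the scatter) is within the scatter, whereas a 12-fold lower number from compound 1 to compound 3 (1.09 log units; beyond the scatter) and a 10-fold lower number from compound 2 to compound 3 (1.01 log units; beyond the scatter) are both large. Those large steps show what installing the (2-aminoethyl)amino group did, but none of the three alters that chain, so the data give no size for this change. The (4-aminocyclohexyl)amino group is therefore expected to give no step beyond the scatter in this assay, though with wide uncertainty. The estimated step is a 1.3-fold lower number from compound 3 to compound 4 (0.10 log units; within the scatter). For compound 4 the estimated value is 50 nM, with an expected range from 15 nM to 190 nM.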

Compound 4, half-maximal inhibitory concentration: 593 nM
Estimate against measurement, compound 4: 12-fold (1.07 log units) below; the whole stated range lies below it.
By their numbers in this assay, from the lowest: compound 3; then compounds 4, 2 and 1 (each within the scatter of the next).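

In this assay, the step of a 9.4-fold higher number from compound 3 to compound 4 (0.97 log units; beyond the scatter) shows that the chain on this nitrogen matters, not only the presence of an amino group on it: 4-aminocyclohexyl does not keep the low number seen with 2-aminoethyl. The steps of a 1.1-fold lower number from compound 2 to compound 4 (0.03 log units; within the scatter) and a 1.3-fold lower number from compound 1 to compound 4 (0.12 log units; within the scatter) are both within the scatter, so among the compounds shown only compound 3 stands apart, and the (4-aminocyclohexyl)amino group sits level with methylsulfonyl and methylsulfanyl on that aromatic carbon. Nothing available explains this difference.

Since 4-aminocyclohexyl brings in both a ring and a larger group, the compounds shown cannot separate these two features. As far as these compounds go, it remains open whether an open chain such as 3-aminopropyl or 4-aminobutyl, or a smaller ring such as 3-aminocyclobutyl, would keep the number of compound 3.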